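The source may hold more compounds than are shown below. What is called first, only, known or untested is meant among the compounds shown, and "the series" means these compounds.

Three compounds share one core and differ only in the group on the far end of the biphenyl. Compound 1 `CCOc1ccc(-c2ccc(N(C[C@@H](N)[C@@H](C)CC)C(=O)[C@@H]3C[C@H]3c3ccccc3)cc2)cc1` gives 90 nM in a functional assay for agonist activity at G protein-coupled receptor 88 (Homo sapiens), read by HTRF and cAMP accumulation; a higher number here means that more compound is needed for the effect, a lower number that less compound is needed. Compound 2 `CC[C@H](C)[C@H](N)CN(C(=O)[C@@H]1C[C@H]1c1ccccc1)c1ccc(-c2ccc(OC(F)(F)F)cc2)cc1` gives 170 nM in this assay, and compound 3 `CC[C@H](C)[C@H](N)CN(C(=O)[C@@H]1C[C@H]1c1ccccc1)c1ccc(-c2ccc(N)cc2)cc1` gives 320 nM. Compound 3 stands beyond the scatter above compound 1, as a 3.6-fold higher number from compound 1 to compound 3 (0.55 log units; beyond the scatter) shows, while its gap to compound 2 is within the scatter: a 1.9-fold higher number from compound 2 to compound 3 (0.27 log units; within the scatter). Compound 1 and compound 2 are also within the scatter of each other: a 1.9-fold higher number from compound 1 to compound 2 (0.28 log units; within the scatter).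

Compound 4 `CC[C@H](C)[C@H](N)CN(C(=O)[C@@H]1C[C@H]1c1ccccc1)c1ccc(-c2ccc(CN(C)C)cc2)cc1` takes the next step at the same place: (dimethylamino)methyl in place of amino on an aromatic carbon. Among the measured compounds shown here, no measured step introduces this group, so the only guide is how little the number has moved with the three groups already tried at this carbon, all within a modest range. On that basis the step from compound 3 to compound 4 in this assay is expected to stay small, a 1.3-fold lower number from compound 3 to compound 4 (0.11 log units; within the scatter), and compound 4 is estimated at 250 nM, with a range from 80 nM to 800 nM.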

Compound 4, half-maximal effective concentration: 460 nM
Compound 4: middle estimate off by 1.8-fold (0.26 log units), on the low side, and the stated range covers the measured number.
By their numbers in this assay, from the lowest: compounds 1, 2, 3 and 4 (each within the scatter of the next, the first and the last beyond it).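

With four heavy atoms in place of one and no hydrogen-bond donor, the (dimethylamino)methyl group of compound 4 still cannot be told apart from the amino group of compound 3 in this assay (a 1.4-fold higher number from compound 3 to compound 4 (0.16 log units; within the scatter)). Among the compounds shown here, it is, however, the first group at this aromatic carbon to lie beyond the scatter of both the trifluoromethoxy and the ethoxy compounds (a 2.7-fold higher number from compound 2 to compound 4 (0.43 log units; beyond the scatter); a 5.1-fold higher number from compound 1 to compound 4 (0.71 log units; beyond the scatter)), though both steps remain modest. Nothing measured here explains these differences.

From the compounds shown here alone, it remains open whether a plain aminomethyl group or a dimethylamino group attached directly to the ring would sit nearer compound 3 or compound 4. Going by these compounds, it is also open where a carboxylic acid or a nitrile at this carbon would fall within the range seen so far.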